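A few compounds are considered here, and "the series" means these few. Any claim that something is new, unique, unknown or untested is made for them only; others in the source may bear on it.

In a functional assay on SMMC-7721 cells (Homo sapiens) for cytotoxicity, read by MTT assay, with a stated time of 72 h (a higher number here means a weaker inhibitor, a lower number a stronger inhibitor), compound 3 `NC(=O)N1CCN(C(=S)SCc2cn(Cc3ccc(F)cc3)nn2)CC1` gives only a limit, > 128000 nM. Compound 1 `NC(=O)N1CCN(C(=S)SCc2cn(Cc3ccccc3F)nn2)CC1` likewise gives only a limit in this assay, > 128000 nM. Compound 2 `O=C(NCc1ccccc1)N1CCN(C(=S)SCc2cn(Cc3ccccc3F)nn2)CC1` also gives only a limit in this assay, > 128000 nM. All three values sit at the same point, (the limit of > 128000 nM in this assay, at which 3 of the 3 values shown sit), so compound 3 stands nowhere distinguishable from compound 1 or compound 2. Compound 4 `CCN(C)C(=O)N1CCN(C(=S)SCc2cn(Cc3ccc(F)cc3)nn2)CC1` differs from compound 3 by ethyl(methyl)amino in place of amino on a carbonyl carbon. Among the measured compounds shown here, two measured steps bear on such a change: a step that the two limits leave unreadable from compound 1 to compound 2, which also alters the carbamoyl nitrogen, and a step that the two limits leave unreadable from compound 1 to compound 3, which connects the two fluorophenyl variants; both leave the size of the step unreadable. For the measured compounds named here, no measured step gives a direction for the change from compound 3 to compound 4, so no step beyond the scatter can be foreseen in this assay, and the most probable outcome is once more a limit. Compound 4 is therefore expected to give about 128000 nM in this assay, within an estimated range of 60000 nM to 300000 nM. This estimate corresponds to an expected step of a number no higher from compound 3 to compound 4 (the limit leaves the size open).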

Compound 4, half-maximal inhibitory concentration: 23700 nM
Compound 4: the middle estimate sits 5.4-fold (0.73 log units) above what was measured; the measured number lies below the stated range.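

In this assay, ethyl(methyl)amino in place of amino on a carbonyl carbon gives an at least 5.4-fold lower number from compound 3 to compound 4 (0.73 log units; beyond the scatter), which shows that this position can change the read-out when the carbonyl carbon carries a fully substituted nitrogen. Compound 2, which carries a benzyl on the amide-type nitrogen, gives only a limit, > 128000 nM. The earlier steps cannot be read, and compound 4 alone gives a number rather than a limit: the limit of > 128000 nM in this assay, at which 3 of the 4 values shown sit.

The compounds shown leave open whether the step follows from the loss of the hydrogen on that nitrogen or from the ethyl and methyl groups themselves, which a methylamino or a diethylamino group on the same carbonyl carbon would separate. They also leave open whether the same change would give a step with 2-fluorophenyl in place of 4-fluorophenyl.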